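The source may hold more compounds than are shown below. What is called first, only, known or untested is meant among the compounds shown, and "the series" means these compounds.

Measured so far in an ADME assay on microsomes from liver (Mus musculus) for metabolic stability, read by LC-MS, with a stated time of 4 h, tested at 1 uM; a higher number here means faster removal of the compound, a lower number slower removal:
compound 1, `Cc1cc(CNc2nc3cc(Cl)c(Cl)cc3[nH]2)ncc1-c1cn(C)nc1C`: 2580 mL/min/kg
compound 2, `CCOc1cc(NC(=O)NCc2cc(C)c(-c3cn(C)nc3C(F)(F)F)nn2)cc(C#N)n1`: < 105 mL/min/kg

The value of compound 2 in this assay is a limit of the assay, not a number. It stands at the limit of < 105 mL/min/kg in this assay, at which 1 of the 2 values shown sits. Among the compounds with values here, compound 1 and compound 2 differ in more than one place, so the pair shows only that compound 1 reads as a high number while compound 2 reads as a limit; no step is drawn between them.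

Compound 3 is `CCOc1nc(C)cc(NC(=O)NCc2cc(C)c(-c3cn(C)nc3C(F)(F)F)nn2)c1Cl` and is not yet measured. It follows from compound 2 by 3-chloro-2-ethoxy-6-methylpyridin-4-yl in place of 2-cyano-6-ethoxypyridin-4-yl on an amide-type nitrogen. Within the data shown here, no measured step matches this change, so nothing anchors its size. The expected step in this assay is an at least 1.4-fold higher number from compound 2 to compound 3 (0.15 log units; that floor lies within the scatter), that is, nothing beyond the scatter or at most a modest rise from the limit. Compound 3 is therefore expected at 150 mL/min/kg, within a range from 60 mL/min/kg to 450 mL/min/kg, with a real chance that the assay again reports only a limit.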

Compound 3, clearance: 250 mL/min/kg
Compound 3: the middle estimate sits 1.7-fold (0.22 log units) below what was measured; low and high end bracket the measured number.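

In this assay, 3-chloro-2-ethoxy-6-methylpyridin-4-yl in place of 2-cyano-6-ethoxypyridin-4-yl on the amide-type nitrogen gives the series its first step across a single change: an at least 2.3-fold higher number from compound 2 to compound 3 (0.37 log units; beyond the scatter). Compound 3 reads as a number, 250 mL/min/kg, so the group on this nitrogen can move the clearance beyond the usual scatter. The size of the step remains a floor because compound 2 carries a limit of the assay, not a number: the limit of < 105 mL/min/kg in this assay, at which 1 of the 3 values shown sits.

The compounds shown do not separate the contributions of the chloro, methyl and cyano parts of this change, since all three differ together between the two groups. As far as these compounds go, how the clearance would respond to an amine in place of the ethoxy on this pyridine remains open.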